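Trimming a Side Chain on a Weak Topoisomerase Inhibitor

The compounds below may be only part of what the source reports. "The series", "measured", "known", "first", "only" and "open" are said of these compounds alone.

Compound 1 `CNCCCNc1c(F)cc2c(=O)c(C(=O)O)cn(Cc3ccc(-c4ccccc4)cc3)c2c1OC` gives 101000 nM.
Compound 2 `CNC(=O)c1cn(Cc2ccc(-c3ccccc3)cc2)c2c(OC)c(N3CC[C@@H](CN)C3)c(F)cc2c1=O` gives 82100 nM.
Compound 3 `O=C(O)c1cn(Cc2ccc(-n3cccn3)cc2)c2cc(NC[C@H]3CCNC3)c(F)cc2c1=O` gives 187000 nM.

All three measured compounds were tested in an assay on isolated protein for inhibition of DNA topoisomerase 1 (Homo sapiens), with a stated time of 15 min (on this read-out higher numbers stand for weaker inhibition and lower numbers for stronger inhibition), and all three sit at the weak end of what such a test reports. Compound 1 has the second highest of the three numbers. Its nearest neighbour is compound 2, whose number is within the usual scatter, and its furthest is compound 3, whose number is also within the scatter. On these numbers, then, the three compounds cannot be told apart.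

The next step leaves the shared core of compound 1 untouched and alters only the chain that hangs from the nitrogen on the aromatic ring. Compound 4 `COc1c(NCCN)c(F)cc2c(=O)c(C(=O)O)cn(Cc3ccc(-c4ccccc4)cc3)c12` differs from compound 1 in one place: amino in place of (methylamino)methyl on a saturated chain carbon, two bonds along the chain from a nitrogen on an aromatic ring. Read one bond further out, the same difference is (3-(methylamino)propyl)amino becoming (2-aminoethyl)amino.

Within the data shown here, no measured pair here shows what such a change does, so there is no basis for expecting a move beyond the scatter in this assay in either direction. Compound 4 is expected to give about 110000 nM, between 40000 nM and 300000 nM, which would be a step of a 1.1-fold higher number from compound 1 to compound 4 (0.04 log units; within the scatter).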

Compound 4, half-maximal inhibitory concentration: > 200000 nM
Compound 4: no number, only a limit; the forecaster's own chance of this, stated with the estimate: 15%; at least 1.8-fold (0.25 log units) between middle value and limit.
By their numbers in this assay, from the lowest: compounds 2, 1 and 3 (each within the scatter of the next, the first and the last beyond it). At a limit, above all of these: compound 4.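

Trimming (3-(methylamino)propyl)amino to (2-aminoethyl)amino gives the first comparison here in which only one place differs, and the step is an at least 1.9-fold higher number from compound 1 to compound 4 (0.29 log units; that floor lies within the scatter). In this assay compound 4 gives > 200000 nM, which is a limit of the assay and not a number. The change at this chain therefore brings no gain in inhibition, but only a floor for the step can be stated, and that floor does not establish a real loss; the true size of the step cannot be read from a result at the limit: the limit of > 200000 nM in this assay, at which 1 of the 4 values shown sits.

The change also shortens the chain and removes the methyl on its end amine in a single step, so the compounds shown do not separate these two differences; a (3-aminopropyl)amino chain or a (2-(methylamino)ethyl)amino chain on the same core would pull them apart. Also open, as far as these compounds go, is whether a longer chain, a dimethylamino group at the chain end or a hydroxyl in place of the end amine would move the number beyond the scatter in either direction.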